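The source may hold more compounds than are shown below. What is called first, only, known or untested is meant among the compounds shown, and "the series" means these compounds.

Measured in a functional assay on SMMC-7721 cells (Homo sapiens) for antiproliferative activity, read by MTT assay, with a stated time of 48 h; on this read-out lower numbers stand for stronger inhibition and higher numbers for weaker inhibition:
- compound 1 `CC[Si](CC)(CC)C/C1=C/C[C@](C)(CCC=C(C)C)/C=C/[C@@H](OC(=O)C=C(C)C)[C@](C)(O)/C=C/C1=O`: 3460 nM
- compound 2 `CSC(=S)OC/C1=C/C[C@](C)(CCC=C(C)C)/C=C/[C@@H](OC(=O)C=C(C)C)[C@](C)(O)/C=C/C1=O`: 720 nM

Of these two compounds, compound 2 has the lower number, 720 nM, so it is the stronger inhibitor here. Compound 3 `CC(C)=CCC[C@]1(C)/C=C/[C@@H](OC(=O)C=C(C)C)[C@](C)(O)/C=C/C(=O)/C(C(=O)N(C)C)=C\C1` has not yet been measured. Its structure differs from that of compound 2 as follows: a group of 5 heavy atoms (3 carbon, 1 nitrogen, 1 oxygen; no ring) in place of a group of 6 heavy atoms (3 carbon, 1 oxygen, 2 sulfur; no ring), on a double-bonded ring carbon. The dimethylcarbamoyl group sits on a double-bonded ring carbon.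

For the measured compounds named here, only one measured step bears on this change: a 4.8-fold lower number from compound 1 to compound 2 (0.68 log units; beyond the scatter). This modest step exchanged one group for another on a saturated chain carbon bound to that same double-bonded ring carbon. It shows that changes in this part of the molecule can move the number beyond the scatter. Going by the values given here, no measured compound carries a dimethylcarbamoyl group, so the direction of the next step remains uncertain. Among the compounds with values here, compound 2 holds the lower of only two numbers, so a modest move towards a higher number is the more likely outcome. The expected change is a 2.5-fold higher number from compound 2 to compound 3 (0.40 log units; beyond the scatter). For compound 3 the estimated value is 1800 nM, with an expected range from 500 nM to 6000 nM.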

Compound 3, half-maximal inhibitory concentration: 3670 nM
For compound 3 the middle estimate is 2.0-fold (0.31 log units) below the measured one, and the stated range covers the measured number.
By their numbers in this assay, from the lowest: compound 2; then compounds 1 and 3 (each within the scatter of the next).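

In this assay, replacing the sulfur-bearing group of compound 2 with dimethylcarbamoyl on the double-bonded ring carbon gives a 5.1-fold higher number from compound 2 to compound 3 (0.71 log units; beyond the scatter) and so loses the low number that compound 2 reached. The other comparison is a 1.1-fold higher number from compound 1 to compound 3 (0.03 log units; within the scatter) and stays within the usual scatter, so dimethylcarbamoyl and the silicon-bearing group of compound 1 cannot be told apart here, even though they differ in their atoms and in how they are attached. Among these three compounds, only compound 2 stands apart from the others, and nothing measured on them accounts for this difference.

On these data alone, it remains open whether the sulfur atoms of compound 2 matter for its lower number, and a simple thioether or a plain hydroxymethyl group at this place would bear on that question. As far as these compounds go, it also remains open how a carboxylic acid, an amine or an amide with a longer chain on its nitrogen would read on this same double-bonded ring carbon.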